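This account rests on a few compounds, and the source may have more. Where it says the series, first, only, none or still open, it means among the compounds named here.

Working notes on the series in an ADME assay on J774 cells (Mus musculus) for cytotoxicity, read by MTT assay, with a stated time of 48 h; a higher number here means a weaker inhibitor, a lower number a stronger inhibitor. For the measured compounds named here, compound 1 `O=Cc1ccccc1OCc1ccc2no[n+]([O-])c2c1` gives 78 uM, the only reading so far that is a number. Compound 2 `CC1(C)[N+]([O-])=c2ccc(COc3ccc(C=O)cc3)cc2=[N+]1[O-]` is reported as < 100 uM, which is a limit. Compound 3 `N=C(N)N/N=C\c1ccccc1OCc1ccc2no[n+]([O-])c2c1` is reported as < 100 uM, also a limit, so it has no exact place in the series. The data are dominated by the limit of < 100 uM in this assay, at which 2 of the 3 values shown sit.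

Compound 4 `NC(=S)N/N=C\c1ccccc1OCc1ccc2no[n+]([O-])c2c1` differs from compound 3 in one place: a group of 3 heavy atoms (1 carbon, 1 nitrogen, 1 sulfur; no ring) in place of a group of 3 heavy atoms (1 carbon, 2 nitrogen; no ring), on an amine nitrogen. Going by the values given here, the only measured step that bears on this change is a step that the limit leaves unreadable from compound 1 to compound 3, and it gives no size to carry over. Among the compounds with values here, no measured step therefore supports a direction, and no shift beyond the scatter is expected. The only numerical anchor for the expectation is compound 1 at 78 uM. The estimated step is a step that the limit leaves unreadable from compound 3 to compound 4, and this remains loose. The expected value for compound 4 is 50 uM, with an estimated range of 15 uM to 100 uM.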

Compound 4, concentration for 50% inhibition: < 100 uM
Compound 4: no number, only a limit; the forecaster's own chance of this, stated with the estimate: 35%; the middle value lies beyond the limit too.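

In this assay compound 4 is reported only as a limit, so no new step can be read from compound 1 or compound 3 to compound 4: the limit of < 100 uM in this assay, at which 3 of the 4 values shown sit.

The compounds shown leave open whether the change on the amine nitrogen between compound 3 and compound 4 shifts the reading at all.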